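Notes on the acetamido end of the series

The source may report more compounds than this note shows. Statements on the series, on what has been measured and on what is new or still open speak of the compounds shown alone.

Values in a functional assay on MV4-11 cells (Homo sapiens) for antiproliferative activity, read by CellTiter-Glo, with a stated time of 72 h (a higher number here means a weaker inhibitor of growth, a lower number a stronger inhibitor of growth), for the measured compounds
- compound 1 `N[C@H]1CC[C@H](Nc2cc(-c3csc(NCC4CCOCC4)n3)c(Cl)cn2)CC1` gives 140 nM
- compound 2 `N[C@H]1CC[C@H](CNc2cc(-c3csc(NCC4CCOCC4)n3)c(Cl)cn2)CC1` gives 1900 nM
- compound 3 `CC(=O)N[C@H]1CC[C@H](Nc2cc(-c3csc(NCC4CCOCC4)n3)c(Cl)cn2)CC1` gives 3600 nM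

Compound 3 gives 3600 nM and sits with compound 2 at the upper end of these numbers. There is a 1.9-fold higher number from compound 2 to compound 3 (0.28 log units; within the scatter) within the scatter and a 26-fold higher number from compound 1 to compound 3 (1.41 log units; beyond the scatter) as a large step with acetyl in place of hydrogen on an amine nitrogen.

Compound 4 `COCC(=O)N[C@H]1CC[C@H](Nc2cc(-c3csc(NCC4CCOCC4)n3)c(Cl)cn2)CC1` differs from compound 3 by methoxy in place of hydrogen on a saturated chain carbon bound to a carbonyl carbon with methoxy in place of hydrogen on a saturated chain carbon bound to a carbonyl carbon. Within the data shown here, no measured step changes the acetyl group itself, so no step beyond the scatter is expected in this assay here. The expected step is a 1.2-fold lower number from compound 3 to compound 4 (0.08 log units; within the scatter) as an estimate only. Compound 4 is expected near 3000 nM with an estimated range from 1200 nM to 8000 nM in this assay.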

Compound 4, concentration for 50% growth inhibition: > 10000 nM
Compound 4: a limit, no number (the forecaster's own chance of this, stated with the estimate: 10%); middle value at least 3.3-fold (0.52 log units) from the limit.
By their numbers in this assay, from the lowest: compound 1; then compounds 2 and 3 (each within the scatter of the next). At a limit, above all of these: compound 4.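

In this assay compound 4 stands at a limit, > 10000 nM, not at a number. The acetyl group is thus not inert to substitution: methoxy in place of hydrogen on a saturated chain carbon bound to a carbonyl carbon gives an at least 2.7-fold higher number from compound 3 to compound 4 (0.44 log units; beyond the scatter), and the (methoxymethyl)carbonyl group set against the unacylated amine gives an at least 71-fold higher number from compound 1 to compound 4 (1.85 log units; beyond the scatter). Both steps are minimum sizes, and their full size cannot be read: the limit of > 10000 nM in this assay, at which 1 of the 4 values shown sits.

On these data alone, whether the change follows the ether oxygen or the longer chain alone stays open. So does how a propanoyl or aminoacetyl group would read here.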